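The source may report more compounds than this note shows. Statements on the series, on what has been measured and on what is new or still open speak of the compounds shown alone.

Measured in a functional assay on MCF7 cells (Homo sapiens) for cytotoxicity, read by MTT assay, with a stated time of 24 h, tested at 16 ug/mL; a higher number here means a stronger effect of the compound at the concentration tested, a lower number a weaker effect:
compound 1, `Cn1c(-c2ccc(NC(=O)CSc3nc4cc(Cl)ccc4o3)cc2)nc(-c2ccccc2)c1-c1ccccc1`: 40%
compound 2, `Cn1c(-c2ccc(NC(=O)CSc3nc4ccccc4s3)cc2)nc(-c2ccccc2)c1-c1ccccc1`: 50.3%
compound 3, `Cn1c(-c2ccc(NC(=O)CN3CCN(c4ccccc4)CC3)cc2)nc(-c2ccccc2)c1-c1ccccc1`: 59.6%

Of the three, compound 3 gives the largest number. Relative to compound 2 the step of a number 9.3 percentage points higher from compound 2 to compound 3 (within the scatter) lies within the scatter, so these two are not separated; relative to compound 1 the step of a number 19.6 percentage points higher from compound 1 to compound 3 (beyond the scatter) is beyond it, as is a number 10.3 percentage points higher from compound 1 to compound 2 (beyond the scatter). All three measured steps concern the group on the saturated chain carbon bound to the carbonyl carbon.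

Compound 4 is `Cn1c(-c2ccc(NC(=O)CN3CCN(Cc4ccc(Cl)cc4)CC3)cc2)nc(-c2ccccc2)c1-c1ccccc1`. The change from compound 3 is 4-chlorobenzyl in place of phenyl on an amine nitrogen in a ring. For the measured compounds named here, no measured step touches the group on the amine nitrogen in the ring; the shared core and the 4-phenylpiperazin-1-yl linkage of compound 3 are retained, so the only guide is the value of compound 3, 59.6%, and the general size of steps seen. No step beyond the scatter is expected in this assay, in either direction.

Compound 4 is estimated at 60%, with a range from 45% to 75%. The expected step of a number 0.4 percentage points higher from compound 3 to compound 4 (within the scatter) therefore stays within the scatter.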

Compound 4, a percentage reported as activity, at one concentration (the size of the read-out at that concentration, not a potency): 46.2%
Beside the measured number, compound 4's estimate is 13.8 percentage points above it, and the stated range covers the measured number.
By their numbers in this assay, from the lowest: compounds 1, 4, 2 and 3 (each within the scatter of the next, the first and the last beyond it).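

In this assay, for the compounds shown here, the group on the amine nitrogen in the ring proves able to shift the read-out: 4-chlorobenzyl in place of phenyl gives a number 13.4 percentage points lower from compound 3 to compound 4 (beyond the scatter), whereas the earlier steps concerned only the group on the saturated chain carbon bound to the carbonyl carbon. Both groups carry one six-membered aromatic ring of carbon only and neither has hydrogen-bond donors or acceptors, so this single pair ties the step to the replacement as a whole, not to the chlorine or the benzyl link alone. No measured evidence on the reason for this step is at hand.

The compounds shown leave open which of these two parts carries the step, and a plain benzyl on this nitrogen would divide them. Also open, on these data alone, is how an acetyl group or a longer chain ending in phenyl would read at this position.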